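The source may hold more compounds than are shown below. What is called first, only, known or untested is meant among the compounds shown, and "the series" means these compounds.

In a functional assay on a cell-free system (plasma, Oryctolagus cuniculus) for inhibition, with stated times of 5 min, 1 min and 6 min (on this read-out lower numbers stand for stronger inhibition and higher numbers for weaker inhibition), compound 1 `CCOCCOn1c(-c2cccc(C#N)c2)nc(C)c1C(=O)OCC` gives 6250 nM and compound 2 `CCOC(=O)COn1c(-c2cccc(C#N)c2)nc(C)c1C(=O)OCC` gives 6800 nM on the same read-out. Within the data shown here, compound 2 thus stands level with compound 1: the one measured step, a 1.1-fold higher number from compound 1 to compound 2 (0.04 log units; within the scatter) as ethoxycarbonyl replaces ethoxymethyl on a saturated chain carbon bound to an oxygen on an aromatic ring, stays within the scatter. Compound 3 `CCOC(=O)c1c(C)nc(-c2cccc(C#N)c2)n1OCCC(=O)O` changes that same place again, with carboxymethyl in place of ethoxycarbonyl on a saturated chain carbon bound to an oxygen on an aromatic ring on the chain. Among the measured compounds shown here, the earlier step bears on this one only loosely: no measured compound carries carboxymethyl. With compound 2 at 6800 nM as the anchor, no shift beyond the scatter in this assay is expected, though with little confidence and no firm direction. The estimated step is a 1.0-fold higher number from compound 2 to compound 3 (0.01 log units; within the scatter) in size. For compound 3 the expected value is 7000 nM with an estimated range from 2500 nM to 20000 nM overall.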

Compound 3, half-maximal inhibitory concentration: > 30000 nM
Compound 3 gave a limit, no number (the forecaster's own chance of this, stated with the estimate: 15%); middle value at least 4.2-fold (0.63 log units) from the limit.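

In this assay compound 3 gives no number, only a limit of the assay: the limit of > 30000 nM in this assay, at which 1 of the 3 values shown sits.

Up to this point the position had seemed to tolerate change, since a 1.1-fold higher number from compound 1 to compound 2 (0.04 log units; within the scatter) stayed within the scatter. Carboxymethyl in place of ethoxycarbonyl on the saturated chain carbon is a different matter, giving an at least 4.4-fold higher number from compound 2 to compound 3 (0.64 log units; beyond the scatter), and carboxy in place of ethoxy gives an at least 4.8-fold higher number from compound 1 to compound 3 (0.68 log units; beyond the scatter); the position therefore does respond to what ends the chain, with weaker inhibition for 2-carboxyethoxy than for either of the other two chains.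

The compounds shown leave open how much of this step belongs to the carboxy group and how much to the chain carrying it, as (ethoxycarbonyl)methoxy and 2-carboxyethoxy differ in both. They also leave open how an amine or an amide at the chain end, or a carboxylic acid on a longer chain, would read.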